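Bromo for fluoro on the styryl sulfone aryl ring

The source may hold more compounds than are shown below. What is called first, only, known or untested is meant among the compounds shown, and "the series" means these compounds.

Measured in a functional assay on SK-OV-3 cells (Homo sapiens); a higher number here means a weaker inhibitor of growth, a lower number a stronger inhibitor of growth:
- compound 1 `COc1cc2ncnc(Nc3ccc(CS(=O)(=O)/C=C/c4ccc(Cl)cc4Cl)cc3)c2cc1OC`: 2000 nM
- compound 2 `COc1cc2ncnc(Nc3ccc(CS(=O)(=O)/C=C/c4ccc(F)cc4)cc3)c2cc1OC`: > 100000 nM (a limit of the assay, not a number)

Compound 2 stands at the limit of > 100000 nM in this assay, at which 1 of the 2 values shown sits. Compound 3 `COc1cc2ncnc(Nc3ccc(CS(=O)(=O)/C=C/c4ccc(Br)cc4)cc3)c2cc1OC` differs from compound 2 by bromo in place of fluoro on an aromatic carbon, para to a large group.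

Among the compounds with values here, one measured step bears on this change: an at least 50-fold higher number from compound 1 to compound 2 (1.69 log units; beyond the scatter). That step is large and shows that the substituents on this aryl ring can move the number strongly in this assay. It does not isolate bromo in place of fluoro, so it gives the likely direction better than the size. A lower number than the limit of compound 2 is expected, possibly a large drop, though compound 3 may also stay at the limit.

The expected change is an at least 6.6-fold lower number from compound 2 to compound 3 (0.82 log units; beyond the scatter). For compound 3 the estimated value is 15000 nM, with an expected range of 2000 nM to 100000 nM.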

Compound 3, concentration for 50% growth inhibition: 50000 nM
Estimate against measurement, compound 3: 3.3-fold (0.52 log units) below; the measured number falls inside the stated range.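

In this assay compound 2 gives > 100000 nM, which is a limit of the assay and not a number. Bromo in place of fluoro gives an at least 2.0-fold lower number from compound 2 to compound 3 (0.30 log units; that floor lies within the scatter), so only a floor is known for this change, and that floor alone does not separate the two compounds. The 4-bromophenyl ring nevertheless gives a number on the scale, and the ring change still leaves a 25-fold higher number from compound 1 to compound 3 (1.40 log units; beyond the scatter), so a single bromo at this place does not match the 2,4-dichlorophenyl ring of compound 1.

Going by these compounds, it remains open whether a 4-chlorophenyl or a 2-chlorophenyl ring would close that gap, which would show how much each chloro of compound 1 contributes. Also open, on these data alone, is how a methoxy or a trifluoromethyl group would read at this place on the ring.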